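Nitrogen substituent step from compound 3 to compound 4

The source may report more compounds than this note shows. Statements on the series, on what has been measured and on what is new or still open speak of the compounds shown alone.

Measured so far in a functional assay on DU-145 cells (Homo sapiens) for cytotoxicity, read by trypan blue exclusion, with a stated time of 96 h (on this read-out lower numbers stand for stronger inhibition and higher numbers for weaker inhibition), for the three compounds:
- compound 1 `COC(=O)CCNc1cc(CS(=O)(=O)/C=C/c2c(OC)cc(OC)cc2OC)ccc1OC` gives 1500 nM
- compound 2 `COC(=O)[C@H](C)Nc1cc(CS(=O)(=O)/C=C/c2c(OC)cc(OC)cc2OC)ccc1OC` gives 750 nM
- compound 3 `COC(=O)C(Nc1cc(CS(=O)(=O)/C=C/c2c(OC)cc(OC)cc2OC)ccc1OC)c1ccc(Cl)cc1` gives 400 nM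

Compound 3 stands at the low end of these numbers. The step of a 1.9-fold lower number from compound 2 to compound 3 (0.27 log units; within the scatter) stays within the scatter, while a 3.8-fold lower number from compound 1 to compound 3 (0.57 log units; beyond the scatter) goes beyond it.

Compound 4 `COc1cc(OC)c(/C=C/S(=O)(=O)Cc2ccc(OC)c(NC(C)(C)C(=O)O)c2)c(OC)c1` is unmeasured. Its difference 1-carboxy-1-methylethyl in place of (4-chlorophenyl)(methoxycarbonyl)methyl on a nitrogen on an aromatic ring is 1-carboxy-1-methylethyl in place of (4-chlorophenyl)(methoxycarbonyl)methyl on a nitrogen on an aromatic ring.

Steps at this nitrogen have been small, with a 2.0-fold lower number from compound 1 to compound 2 (0.30 log units; within the scatter) as the other example, and no measured compound carries a carboxy group. A small move to a higher number in this assay is therefore expected. The expected step is a 1.9-fold higher number from compound 3 to compound 4 (0.27 log units; within the scatter) and so not clearly beyond the scatter. The estimate for compound 4 is 750 nM within an expected range of 150 nM to 3500 nM on present evidence.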

Compound 4, half-maximal inhibitory concentration: 150 nM
For compound 4 the middle estimate is 5.0-fold (0.70 log units) above the measured one; measured number inside the range.
By their numbers in this assay, from the lowest: compound 4; then compounds 3, 2 and 1 (each within the scatter of the next, the first and the last beyond it).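

At the nitrogen on an aromatic ring, the largest changes so far come with 1-carboxy-1-methylethyl in this assay: a 2.7-fold lower number from compound 3 to compound 4 (0.43 log units; beyond the scatter), a 5.0-fold lower number from compound 2 to compound 4 (0.70 log units; beyond the scatter) and a 10-fold lower number from compound 1 to compound 4 (1.00 log units; beyond the scatter). Going by these compounds alone, compound 4 therefore has the lowest number, and this is the first carboxy group at this position. A low number here does not require the six-membered aromatic ring of (4-chlorophenyl)(methoxycarbonyl)methyl, since 1-carboxy-1-methylethyl has no ring.

The methyl ester of 1-carboxy-1-methylethyl and the 1-carboxyethyl group would separate the part played by the carboxy group from that of the second methyl. No evidence is available on why the number falls.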